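The source may hold more compounds than are shown below. What is called first, only, known or untested is meant among the compounds shown, and "the series" means these compounds.

Compound 3 `CCCCCCCCc1ccc(OCC(=O)Cn2nnnc2C(=O)OCC)cc1` gives 940 nM in an assay on microsomes from brain for inhibition of Fatty-acid amide hydrolase 1 (Rattus norvegicus), read by fluorescence and HPLC, with a stated time of 60 min; a higher number here means a weaker inhibitor, a lower number a stronger inhibitor. Among the three measured compounds it stands second highest: its nearest neighbour is compound 2 `CCCCCCCCc1ccc(OCC(=O)Cn2nnnc2-c2ccccn2)cc1`, which gives 880 nM in this assay, and the gap between them, a 1.1-fold higher number from compound 2 to compound 3 (0.03 log units; within the scatter), lies within the scatter. Its furthest neighbour is compound 1 `CCCCCCCCc1ccc(OCC(=O)Cn2nnnc2-c2cccc(S(=O)(=O)N(C)C)c2)cc1`, which gives 1900 nM in this assay; the step of a 2.0-fold lower number from compound 1 to compound 3 (0.31 log units; beyond the scatter) is modest but beyond the scatter, as is the related step of a 2.2-fold lower number from compound 1 to compound 2 (0.33 log units; beyond the scatter).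

Compound 4 `CCCCCCCCc1ccc(OCC(=O)Cn2nnnc2-c2cccc(C(=O)O)c2)cc1` differs from compound 3 by 3-carboxyphenyl in place of ethoxycarbonyl on an aromatic carbon. Among the compounds with values here, the one measured step that bears on this change is the step from compound 1 to compound 3, in which a substituted phenyl on the same aromatic carbon was exchanged for ethoxycarbonyl and the number fell by a modest amount. Within the data shown here, compound 4 restores a substituted phenyl at that carbon, though with a different substituent, so a modest rise in the number, of roughly the size seen between compound 1 and compound 3, is expected, with the proviso that the new substituent has no precedent among the measured compounds. The step from compound 3 to compound 4 in this assay is therefore expected to be about a 1.9-fold higher number from compound 3 to compound 4 (0.28 log units; within the scatter). Compound 4 is estimated to give 1800 nM in this assay, within a range from 600 nM to 6000 nM.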

Compound 4, half-maximal inhibitory concentration: 1800 nM
Beside the measured number, compound 4's estimate shows no gap at the digits printed, within the range that was stated.
By their numbers in this assay, from the lowest: compounds 2, 3, 4 and 1 (each within the scatter of the next, the first and the last beyond it).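

In this assay, within the data shown here, this is the first change made within the substituted phenyl itself while the phenyl stays on the aromatic carbon of the ring, and carboxy in place of dimethylsulfamoyl leaves the result within the scatter: a 1.1-fold lower number from compound 1 to compound 4 (0.02 log units; within the scatter). The 3-carboxyphenyl group also cannot be separated from ethoxycarbonyl, as a 1.9-fold higher number from compound 3 to compound 4 (0.28 log units; within the scatter) stays within the scatter, although the dimethylsulfamoyl compound was separated from ethoxycarbonyl by a modest step; against pyridin-2-yl, however, the gap is modest but beyond the scatter, with a 2.0-fold higher number from compound 2 to compound 4 (0.31 log units; beyond the scatter), so both substituted phenyl compounds now stand apart from compound 2, while compound 3 falls within the scatter of compound 2 and of compound 4 and so fits neither side of that split. No measurement is at hand that would explain why these groups compare as they do.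

Going by these compounds, whether a plain phenyl, or a phenyl carrying an amine or a methyl ester, would group with compound 1 and compound 4 or with compound 2 stays open. So does how a carboxylic acid placed directly on that aromatic carbon would compare with the ethoxycarbonyl of compound 3.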